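Notes on compounds 1 to 4: carbamoylamino in place of halophenyl

The source may report more compounds than this note shows. Statements on the series, on what has been measured and on what is new or still open speak of the compounds shown alone.

Measured so far in a functional assay on HeLa cells (Homo sapiens) for inhibition, read by MTT assay, with a stated time of 72 h; a higher number here means a weaker inhibitor, a lower number a stronger inhibitor:
Compound 1 `COc1cc(NC(C)CCCNC(=O)Nc2ccc(Br)cc2)c2ncccc2c1` gives 20000 nM.
Compound 3 `COc1cc(NC(C)CCCNC(=O)Nc2ccc(Cl)cc2)c2ncccc2c1` gives 18000 nM.
Compound 2 `COc1cc(NC(C)CCCNC(=O)NNC(=O)Nc2cccc(F)c2)c2ncccc2c1` returns only a limit, > 250000 nM.

Compound 1 has the highest of the two numbers, and compound 3 lies nearest, a 1.1-fold lower number from compound 1 to compound 3 (0.05 log units; within the scatter). Compound 4 `COc1cc(NC(C)CCCNC(=O)NNC(=O)Nc2ccc(O)cc2)c2ncccc2c1` carries the change (((4-hydroxyphenyl)carbamoyl)amino in place of 4-bromophenyl on an amide-type nitrogen). The measured steps that bear on it are the same kind of exchange, an at least 12-fold higher number from compound 1 to compound 2 (1.09 log units; beyond the scatter), and its reverse, an at least 13-fold lower number from compound 2 to compound 3 (1.14 log units; beyond the scatter); both are large. Because compound 2 reached the limit of > 250000 nM in this assay, at which 1 of the 3 values shown sits, with the same carbamoylamino linkage, compound 4 is expected to show a large upward step, a 13-fold higher number from compound 1 to compound 4 (1.10 log units; beyond the scatter), with a fair chance that this assay again returns only a limit. Compound 4 is estimated at 250000 nM, within 60000 nM to 1000000 nM.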

Compound 4, half-maximal inhibitory concentration: 85000 nM
Compound 4: middle estimate off by 2.9-fold (0.47 log units), on the high side, and the stated range covers the measured number.
By their numbers in this assay, from the lowest: compounds 3 and 1 (each within the scatter of the next); then compound 4. At a limit, above all of these: compound 2.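

In this assay the carbamoylamino linkage now gives a measured number rather than only a limit, so the exchange has a size: a 4.3-fold higher number from compound 1 to compound 4 (0.63 log units; beyond the scatter), and a 4.7-fold higher number from compound 3 to compound 4 (0.67 log units; beyond the scatter). With the linkage held, 4-hydroxyphenyl in place of 3-fluorophenyl gives an at least 2.9-fold lower number from compound 2 to compound 4 (0.46 log units; beyond the scatter), so the aromatic group on the linkage also counts. Compound 2 itself remains at a limit: the limit of > 250000 nM in this assay, at which 1 of the 4 values shown sits.

Open, from the compounds shown here alone, is how far the linkage alone accounts for the higher numbers, apart from the aromatic group it carries. Also open, going by these compounds, is how a 4-aminophenyl or 4-carboxyphenyl group on the same linkage would read.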